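A few compounds are considered here, and "the series" means these few. Any claim that something is new, unique, unknown or untested is made for them only; others in the source may bear on it.

Measured compounds:
Compound 1, `COc1cc(NC(=O)Nc2cc(Nc3ccc(OC)c(C)c3)ncn2)cc(OC)c1`: 62%
Compound 2, `CCc1cccc(Nc2cc(NC(=O)Nc3cc(OC)cc(OC)c3)ncn2)c1`: 82.1%
Compound 3, `COc1cc(NC(=O)Nc2cc(Nc3ccc(Br)cc3OC)ncn2)cc(OC)c1`: 83%

The three compounds share one core and differ only in the aryl group on a nitrogen on an aromatic ring. In a functional assay on PC-9 cells (Homo sapiens) for inhibition, read by MTT assay, with a stated time of 48 h, tested at 10 uM (on this read-out higher numbers stand for more inhibition at the one concentration tested (going by the name of the read-out) and lower numbers for less inhibition), compound 3 gives the highest of the three numbers, yet its nearest neighbour is compound 2, which lies within the scatter of it, as a number 0.9 percentage points higher from compound 2 to compound 3 (within the scatter) shows; only compound 1 is clearly lower, the gap being a number 21 percentage points higher from compound 1 to compound 3 (beyond the scatter).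

The unmeasured compound 4, `CCc1ccc(Nc2cc(NC(=O)Nc3cc(OC)cc(OC)c3)ncn2)cc1`, takes the step (4-ethylphenyl in place of 4-bromo-2-methoxyphenyl on a nitrogen on an aromatic ring). Within the data shown here, two measured steps bear on it. Compound 2 already carries an ethylphenyl group, as 3-ethylphenyl, in the same place, and its step to compound 3, a number 0.9 percentage points higher from compound 2 to compound 3 (within the scatter), stayed within the scatter. The step from compound 1, a number 20.1 percentage points higher from compound 1 to compound 2 (beyond the scatter), shows that an ethylphenyl group can stand well above a methoxy-methyl pattern. Among the measured compounds shown here, no measured step compares 4-ethylphenyl with 3-ethylphenyl, so that part of the change is open.

Compound 4 is therefore expected to stay close to compound 3, with a step of a number 5 percentage points lower from compound 3 to compound 4 (within the scatter) in this assay, and its value is estimated at 78%, within 60% to 92%.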

Compound 4, a percentage reported as inhibition, at one concentration (the size of the read-out at that concentration, not a potency): 78%
Compound 4: middle estimate and measured number agree at the digits printed; low and high end bracket the measured number.
By their numbers in this assay, from the lowest: compound 1; then compounds 4, 2 and 3 (each within the scatter of the next).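

In this assay, among these compounds, the new compound gives the first comparison of the two ethylphenyl groups, a number 4.1 percentage points lower from compound 2 to compound 4 (within the scatter) and so 4-ethylphenyl and 3-ethylphenyl cannot be told apart at this position on a nitrogen on an aromatic ring. Exchanging 4-bromo-2-methoxyphenyl for 4-ethylphenyl, a group of carbon atoms alone, gives a number 5 percentage points lower from compound 3 to compound 4 (within the scatter) and this shows that neither the bromine nor the methoxy group is required among these compounds to reach the level of compound 3. The step of a number 16 percentage points higher from compound 1 to compound 4 (beyond the scatter) adds a third aryl group that stands clear of the 4-methoxy-3-methylphenyl group of compound 1, leaving compound 1 as the only one of the four set apart from the others.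

The compounds shown leave open how a morpholine, a carboxylic acid or a longer chain such as butyl in place of the ethyl group would read at this position, and a reading at a single concentration does not say whether compounds 2, 3 and 4 would differ in the size of their effect at any other concentration. Nothing available here offers an explanation for these numbers.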